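The compounds below may be only part of what the source reports. "The series", "measured", "known", "first", "only" and "open" are said of these compounds alone.

Measured compounds: compound 1 `CCC[C@@H]1NC(=O)[C@@H](C(C)C)NC(=O)[C@@H](CCC(=O)O)NCCOc2ccccc2/C=C/CNC1=O` with > 10000 nM; compound 2 `CC(C)[C@H]1NC(=O)[C@@H](Cc2ccc(O)cc2)NCCOc2ccccc2/C=C/CNC(=O)[C@H](C)NC1=O` with 1390 nM.

In an assay on isolated protein for displacement of a labelled ligand from Motilin receptor (Homo sapiens) (a higher number here means a weaker inhibitor, a lower number a stronger inhibitor), compound 1 gives > 10000 nM, which is a limit of the assay rather than a number, as noted in the limit of > 10000 nM in this assay, at which 1 of the 2 values shown sits. Among the measured compounds shown here, compound 2 is the only compound with an actual number in this assay, 1390 nM. Compound 3 `CC(C)[C@H]1NC(=O)[C@@H](Cc2ccc(O)cc2)NCCOc2ccccc2/C=C/CNC(=O)[C@H](CO)NC1=O` differs from compound 2 by hydroxy in place of hydrogen on a saturated chain carbon bound to a saturated ring carbon. For the measured compounds named here, no measured step of this kind exists, so the expected change is small: compound 3 is estimated at 1000 nM (range 300 nM to 3500 nM), a step of a 1.4-fold lower number from compound 2 to compound 3 (0.14 log units; within the scatter) expected to stay within the scatter.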

Compound 3, inhibition constant: 650 nM
The estimate for compound 3 lay 1.5-fold (0.19 log units) above the measured number, and the stated range covers the measured number.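

Going from methyl to hydroxymethyl on a saturated chain carbon bound to a saturated ring carbon gives, in this assay, a 2.1-fold lower number from compound 2 to compound 3 (0.33 log units; beyond the scatter) and is the only single-place comparison among the compounds shown. It shows that this position accepts a hydroxy group and that the number responds to the change, modestly but beyond the scatter. Nothing measured here bears on the cause of this step.

As far as these compounds go, whether the hydroxy group itself matters or any similar group would serve remains open. An amine, a carboxylic acid or a longer chain at this place would help to settle that.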